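The source may hold more compounds than are shown below. What is called first, only, known or untested is meant among the compounds shown, and "the series" means these compounds.

Series notes. The shared core of compound 1 `Cc1cc(NC(=O)c2ccc(Cl)cc2)ccc1NS(C)(=O)=O` carries a methylsulfonyl amide on one ring and a chlorobenzamide on the other; in an ADME assay on HEK293 cells (Homo sapiens) for cytotoxicity, read by MTT assay, with a stated time of 48 h (on this read-out lower numbers stand for stronger inhibition and higher numbers for weaker inhibition), compound 1 gives 50300 nM. Compound 2 `Cc1cc(NC(=O)c2ccc(Cl)cc2)ccc1NS(=O)(=O)C(F)(F)F` replaces the methyl on the sulfonyl sulfur with trifluoromethyl, and in this assay compound 2 gives 201000 nM, the highest of the two numbers in hand; the step of a 4.0-fold higher number from compound 1 to compound 2 (0.60 log units; beyond the scatter) lies beyond the scatter. Compound 3 `Cc1cc(NC(=O)c2ccc(C#N)cc2)ccc1NS(=O)(=O)C(F)(F)F` carries cyano in place of chloro, and for compound 3 this assay reports only a limit, > 250000 nM; the step of an at least 1.2-fold higher number from compound 2 to compound 3 (0.09 log units; that floor lies within the scatter) therefore has a floor that lies within the scatter, and the limit of > 250000 nM in this assay, at which 1 of the 3 values shown sits, marks the ceiling of the measurement.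

Compound 4 `O=C(Nc1ccc(NS(=O)(=O)C(F)(F)F)c(Cl)c1)c1ccc(Cl)cc1` is the next step from compound 2: chloro in place of methyl on an aromatic carbon. Neither measured step touches this position: one changed the group on the sulfonyl sulfur, the other the substituent on the benzamide ring. Among the measured compounds shown here, there is thus no measured step that bears directly on the change from compound 2 to compound 4, and no step beyond the scatter is expected in this assay. The step of a 1.1-fold lower number from compound 2 to compound 4 (0.05 log units; within the scatter) is an estimate on that basis. For compound 4 the expected value in this assay is 180000 nM, within 70000 nM to 300000 nM, with a fair chance that only a limit is reported.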

Compound 4, half-maximal inhibitory concentration: 191000 nM
Compound 4: the middle estimate sits 1.1-fold (0.03 log units) below what was measured; the range from low to high includes it.
By their numbers in this assay, from the lowest: compound 1; then compounds 4 and 2 (each within the scatter of the next). At a limit, above all of these: compound 3.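

Among the compounds shown here, the step at this position reads a 1.1-fold lower number from compound 2 to compound 4 (0.02 log units; within the scatter) in this assay, and it is the first measured change on the aromatic carbon ortho to a ((trifluoromethyl)sulfonyl)amino group. Unlike the exchange on the sulfonyl sulfur, whose step is printed as beyond the scatter, chloro in place of methyl here does not separate the two compounds, so on this read-out, with the trifluoromethyl sulfonyl group and the chlorobenzamide held fixed, the two groups cannot be told apart. Compound 3 is reported only as a limit, and this is the one value in the series that is not a number: the limit of > 250000 nM in this assay, at which 1 of the 4 values shown sits.

For the compounds shown here, it remains open whether the same exchange would also give no separable step with the methylsulfonyl amide of compound 1 or with the cyano benzamide of compound 3 in place. Also open is how this position responds to groups of a different kind, such as an amine, a carboxylic acid or a longer chain, since methyl and chloro are the only two groups shown on this carbon.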